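The source may report more compounds than this note shows. Statements on the series, on what has been measured and on what is new or still open speak of the compounds shown alone.

Compound 1 `CCCCNc1nc(N)nc(C)c1CCCCO` is the weaker of the two measured entries in an assay on HEK293 cells for agonist activity at Toll-like receptor 8 (Homo sapiens), read by spectrophotometry; a lower number here means that less compound is needed, a higher number that more compound is needed for the effect: compound 1 gives 1310 nM, the highest of the two numbers. Compound 2 `CCCCNc1nc(N)nc(C)c1CCCN1CCCCCC1` carries azepan-1-yl where compound 1 has hydroxymethyl, and in this assay compound 2 gives 178 nM. The measured step of a 7.4-fold lower number from compound 1 to compound 2 (0.87 log units; beyond the scatter) is the only one to draw on.

Compound 3 `CCCCNc1nc(N)nc(C)c1CCCN1CCCC1` differs from compound 1 as follows: pyrrolidin-1-yl in place of hydroxymethyl on a saturated chain carbon, three bonds along the chain from an aromatic carbon. The group entering is again a saturated nitrogen ring, now a five-membered one with a single hetero atom, replacing the hydroxymethyl at the same place on the chain. The step from compound 1 to compound 2 is the direct comparison, since it swaps the same hydroxymethyl for another such ring at the same position and lowered the number beyond the scatter. A step of similar direction is therefore expected for compound 3, though with a smaller ring the size cannot be read from one example; the expected step is a 5.0-fold lower number from compound 1 to compound 3 (0.70 log units; beyond the scatter). Compound 3 is estimated at 260 nM, with a range of 100 nM to 700 nM.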

Compound 3, half-maximal effective concentration: 110 nM
Estimate against measurement, compound 3: 2.4-fold (0.37 log units) above; measured number inside the range.
By their numbers in this assay, from the lowest: compounds 3 and 2 (each within the scatter of the next); then compound 1.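

In this assay, a second saturated nitrogen ring in place of hydroxymethyl, on a saturated chain carbon three bonds along the chain from an aromatic carbon, again gives a lower number (here a 12-fold lower number from compound 1 to compound 3 (1.08 log units; beyond the scatter)) and this step is large. The drop seen with azepan-1-yl is therefore no longer a single case: both ring-bearing compounds fall in the same direction against compound 1, and none of the three compounds goes against this. Exchanging one ring for the other gives a 1.6-fold lower number from compound 2 to compound 3 (0.21 log units; within the scatter) and so does not separate pyrrolidin-1-yl from azepan-1-yl, which means the data show no effect of ring size across these two rings, and nothing available explains the difference between the rings and hydroxymethyl.

Still open, going by these compounds, is whether the ring is needed at all or an open-chain amine such as diethylamino at the same place would give a similar number, and whether piperidin-1-yl or morpholin-4-yl would stay level with compounds 2 and 3. Also open is how a shorter or longer chain carrying pyrrolidin-1-yl would read, since all three compounds shown keep the same chain length and the same butylamino group on the shared core.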